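Replacing a propargyl chain with a methylsulfonylpropyl chain

A few compounds are considered here, and "the series" means these few. Any claim that something is new, unique, unknown or untested is made for them only; others in the source may bear on it.

Measured so far:
- compound 1, `Nc1nc2ccc(OC(F)(F)C(F)F)cc2s1`: 8.5 mg/kg
- compound 2, `Nc1nc2ccc(OC(F)(F)C(F)(F)F)cc2s1`: 2.5 mg/kg
- compound 3, `C#CCn1c(=N)sc2cc(OC(F)(F)F)ccc21`: 4 mg/kg

In a functional assay on the whole organism with Rattus norvegicus as the target (a lower number here means that less compound is needed, a higher number that more compound is needed for the effect), compound 3 sits second highest of the three numbers. Going by the values given here, its value lies within the scatter of compound 2 and differs from compound 1 by a gap beyond the scatter; no single-point step links compound 3 to either of them, so only the bare values can be compared. Among the compounds with values here, the one measured step, a 3.4-fold lower number from compound 1 to compound 2 (0.53 log units; beyond the scatter), concerns the aryl ether and not the chain on the ring nitrogen.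

Compound 4, `CS(=O)(=O)CCCn1c(=N)sc2cc(OC(F)(F)F)ccc21`, differs from compound 3 by 2-(methylsulfonyl)ethyl in place of ethynyl on a saturated chain carbon bound to an aromatic nitrogen. Within the data shown here, no measured pair bears on this change, so nothing in the set points in either direction, and the shift of a 3.4-fold lower number from compound 1 to compound 2 (0.53 log units; beyond the scatter) cannot be transferred to it. The expectation is therefore a step of modest size at most, with no firm sign.

On that basis compound 4 is estimated at 6 mg/kg, between 2 mg/kg and 18 mg/kg in this assay, which would mean a step of a 1.5-fold higher number from compound 3 to compound 4 (0.18 log units; within the scatter).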

Compound 4, dose for half-maximal effect: 5 mg/kg
For compound 4 the middle estimate is 1.2-fold (0.08 log units) above the measured one, within the range that was stated.
By their numbers in this assay, from the lowest: compounds 2, 3, 4 and 1 (each within the scatter of the next, the first and the last beyond it).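

In this assay, putting 2-(methylsulfonyl)ethyl in place of ethynyl on a saturated chain carbon bound to an aromatic nitrogen gives a 1.3-fold higher number from compound 3 to compound 4 (0.10 log units; within the scatter), so the propargyl and 3-(methylsulfonyl)propyl chains cannot be told apart in this read-out. Going by these compounds alone, this is the first measured step at this position, and it shows that a larger chain carrying hydrogen-bond acceptors and no triple bond can stand here without a shift beyond the scatter. No accompanying measurement offers an explanation for this result.

The compounds shown leave open how a carboxylic acid, an amine or a longer chain would fare at the same place. Going by these compounds, it also remains open whether the 3-(methylsulfonyl)propyl chain would give a similar result alongside the aryl ether of compound 2.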